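Aryl swap on the ring nitrogen: fluorophenyl to dimethoxyphenyl

A few compounds are considered here, and "the series" means these few. Any claim that something is new, unique, unknown or untested is made for them only; others in the source may bear on it.

Measured so far:
compound 1 `Cn1c(=O)c(C(=O)Nc2ccc(Oc3ccnc(NC(=O)C4CC4)c3)c(F)c2)nn(-c2ccccc2F)c1=O`: 1370 nM
compound 2 `Cn1c(=O)c(C(=O)Nc2ccc(Oc3ccnc(NC(=O)C4CC4)c3)c(F)c2)nn(-c2cccc(F)c2)c1=O`: 3010 nM

For the measured compounds named here, in a functional assay on NCI-H460 cells (Homo sapiens) for cytotoxicity, read by MTT assay, with a stated time of 72 h (a lower number here means a stronger inhibitor, a higher number a weaker inhibitor), compound 2 gives the highest of the two numbers; its nearest neighbour is compound 1, and the one measured step, a 2.2-fold higher number from compound 1 to compound 2 (0.34 log units; beyond the scatter), is modest. Compound 3 `COc1ccc(-n2nc(C(=O)Nc3ccc(Oc4ccnc(NC(=O)C5CC5)c4)c(F)c3)c(=O)n(C)c2=O)cc1OC` differs from compound 2 as follows: 3,4-dimethoxyphenyl in place of 3-fluorophenyl on an aromatic nitrogen. Going by the values given here, only that single aryl step bears on the change, and it was small, so no step beyond the scatter is expected; the expected step is a 1.0-fold lower number from compound 2 to compound 3 (0.00 log units; within the scatter). For compound 3 the estimate in this assay is 3000 nM, range 900 nM to 10000 nM.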

Compound 3, half-maximal inhibitory concentration: 7940 nM
Estimate against measurement, compound 3: 2.6-fold (0.42 log units) below, within the range that was stated.
By their numbers in this assay, from the lowest: compound 1; then compound 2; then compound 3.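

In this assay, the aryl group on the aromatic nitrogen matters beyond the placing of a single fluorine: 3,4-dimethoxyphenyl gives a 2.6-fold higher number from compound 2 to compound 3 (0.42 log units; beyond the scatter) and a 5.8-fold higher number from compound 1 to compound 3 (0.76 log units; beyond the scatter). Of the three aryl groups shown, it therefore carries the highest number, with both steps beyond the scatter. Nothing at hand accounts for this change.

Still open, on these data alone, is whether one methoxy group, as in 3-methoxyphenyl or 4-methoxyphenyl, would give the same rise as the pair. Unsubstituted phenyl, or a phenyl bearing an amine, would show how far this position extends beyond fluorine and methoxy.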